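Three Anilinopyrimidine Ethers and One Cytotoxicity Value Still Open

The compounds below may be only part of what the source reports. "The series", "measured", "known", "first", "only" and "open" are said of these compounds alone.

Compound 1 `Cc1ccc(C(=O)c2cc(Cl)ccc2Oc2ccnc(Nc3ccc(C#N)cc3)n2)cc1`: 1710 nM
Compound 2 `Cc1ccccc1C(=O)c1cc(Cl)ccc1Oc1ccnc(Nc2ccc(C#N)cc2)n1`: 28800 nM
Compound 3 `N#Cc1ccc(Nc2nccc(Oc3ccc(C(=O)c4ccc(O)cc4)cc3)n2)cc1`: 19400 nM

In an ADME assay on MT4 cells (Homo sapiens) for cytotoxicity, read by MTT assay, with a stated time of 5 days (on this read-out higher numbers stand for lower toxicity in this test and lower numbers for higher toxicity in this test), compound 3 sits second highest of the three numbers. Compound 3 and compound 2 lie within the scatter of each other, while compound 1 gives a lower number than compound 3, a gap beyond the scatter. Compound 4 `COCCc1ccc(Oc2ccnc(Nc3ccc(C#N)cc3)n2)cc1` differs from compound 3 by 2-methoxyethyl in place of (4-hydroxyphenyl)carbonyl on an aromatic carbon. Going by the values given here, the only measured step, a 17-fold higher number from compound 1 to compound 2 (1.23 log units; beyond the scatter), moves a methyl on the carbonyl-bound ring and does not touch the carbonyl itself, so no measured step bears directly on this change. The step expected is therefore a 1.0-fold higher number from compound 3 to compound 4 (0.01 log units; within the scatter), with nothing beyond the scatter foreseen. Compound 4 is estimated at 20000 nM, within 5000 nM to 80000 nM.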

Compound 4, half-maximal cytotoxic concentration: 93300 nM
The estimate for compound 4 lay 4.7-fold (0.67 log units) below the measured number; the measured number lies above the stated range.
By their numbers in this assay, from the lowest: compound 1; then compounds 3 and 2 (each within the scatter of the next); then compound 4.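

In this assay, the change on this aromatic carbon gives a 4.8-fold higher number from compound 3 to compound 4 (0.68 log units; beyond the scatter), the first measured sign that replacing the whole (4-hydroxyphenyl)carbonyl moves this read-out. The change removes the ring, the carbonyl and the hydrogen-bond donor together, and compound 4 cannot separate their contributions. Nothing measured here accounts for the rise. Still open, as far as these compounds go, is whether an acetyl group, which keeps a carbonyl without the ring, stays nearer compound 3 or compound 4. Also open, from the compounds shown here alone, is how a 2-hydroxyethyl chain or an amine would read at this carbon.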